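Replacing the Pyridyl Ring with a Hydroxyphenyl Group

This account rests on a few compounds, and the source may have more. Where it says the series, first, only, none or still open, it means among the compounds named here.

Compound 2 `CCOC(=O)CCCCCOc1cccc(CN(C(=O)c2ccc(-c3cccnc3)cc2)C(C)C)c1` was tested in an ADME assay on BJ cells (Homo sapiens) for cytotoxicity, read by CellTiter-Glo and resazurin assay, with a stated time of 72 h; a higher number here means that more compound is needed for the effect, a lower number that less compound is needed. In this assay compound 2 gives > 26000 nM, which is a limit of the assay and not a number. Compound 1 `COc1cccc(-c2ccc(C(=O)N(Cc3cccc(OCCCCCC(=O)O)c3)C(C)C)cc2)c1` was examined in the same way; in this assay compound 1 gives > 20900 nM, also a limit of the assay. Among the measured compounds shown here, both measured compounds thus sit at a limit, the limit of > 20900 nM in this assay, at which 1 of the 2 values shown sits, and (the limit of > 26000 nM in this assay, at which 1 of the 2 values shown sits), so no step between measured compounds can be drawn from them. Compound 3 `CCOC(=O)CCCCCOc1cccc(CN(C(=O)c2ccc(-c3cccc(O)c3)cc2)C(C)C)c1` has not yet been tested in this assay. It differs from compound 2 in one place: 3-hydroxyphenyl in place of pyridin-3-yl on an aromatic carbon. Since compound 2 sits at the limit of > 26000 nM in this assay, at which 1 of the 2 values shown sits, the step of a number no higher from compound 2 to compound 3 (the limit leaves the size open) is expected to be none beyond the scatter, in neither direction. Compound 3 is therefore estimated to give 26000 nM in this assay, between 10000 nM and 70000 nM, and will most likely again be reported only as a limit.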

Compound 3, half-maximal effective concentration: > 26000 nM
Compound 3: no number, only a limit; the forecaster's own chance of this, stated with the estimate: 80%; the middle value sits exactly at the limit.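

No new step can be read from compound 2 to compound 3, as both give only a limit in this assay: the limit of > 26000 nM in this assay, at which 2 of the 3 values shown sit.

The compounds shown leave open whether 3-hydroxyphenyl in place of pyridin-3-yl changes the concentration needed for the effect at all.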